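This account rests on a few compounds, and the source may have more. Where it says the series, first, only, none or still open, it means among the compounds named here.

Measured compounds in a functional assay on HeLa cells (Homo sapiens) for cytotoxicity, with a stated time of 72 h; a lower number here means a stronger inhibitor, a higher number a weaker inhibitor:

Compound 1, `Clc1ccc(Cc2nn3cc(-c4ccccc4)nc3s2)cc1`. In this assay compound 1 gives > 250000 nM, a limit of the assay rather than a number.
Compound 2, `O=Cc1c(-c2ccc(Cl)cc2Cl)nc2sc(Cc3ccc(Cl)cc3)nn12`. In this assay compound 2 gives 64000 nM.

Compound 2 thus holds the only number shown; the other value is a limit, (the limit of > 250000 nM in this assay, at which 1 of the 2 values shown sits). For the measured compounds named here, compound 1 and compound 2 differ in more than one place, so no single step between them can be drawn; their values show only that compound 2 yields a number where compound 1 does not.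

Compound 3, `O=Cc1c(-c2ccccc2)nc2sc(Cc3ccc(Cl)cc3)nn12`, is not yet measured. It differs from compound 2 by phenyl in place of 2,4-dichlorophenyl on an aromatic carbon. Going by the values given here, no measured step covers this change. Because compound 1, which also carries phenyl, sits at the limit > 250000 nM, weaker inhibition is expected. The step from compound 2 to compound 3 is expected to be a 2.0-fold higher number from compound 2 to compound 3 (0.31 log units; beyond the scatter), beyond the scatter, toward weaker inhibition. Compound 3 is expected to give about 130000 nM, within 40000 nM to 300000 nM, with a real chance that only a limit is reported.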

Compound 3, half-maximal inhibitory concentration: 45000 nM
The estimate for compound 3 lay 2.9-fold (0.46 log units) above the measured number; measured number inside the range.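

In this assay, the change at this aromatic carbon from 2,4-dichlorophenyl to phenyl gives a 1.4-fold lower number from compound 2 to compound 3 (0.15 log units; within the scatter), so the two chlorine atoms make no readable difference in this pair. Formyl in place of hydrogen on an aromatic carbon can now be read alone, as an at least 5.5-fold lower number from compound 1 to compound 3 (0.74 log units; beyond the scatter), and it is the only one of the two steps beyond the scatter. This step is a bound and not an exact size, because the value of compound 1 is a limit of the assay: the limit of > 250000 nM in this assay, at which 1 of the 3 values shown sits.

Still open, as far as these compounds go, is whether the formyl group itself matters or whether a hydroxymethyl, a carboxylic acid or an amine on the same carbon would give a similar number. Also open, from the compounds shown here alone, is how the aromatic ring responds to groups other than chlorine, such as methoxy or a nitrile.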